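The source may hold more compounds than are shown below. What is called first, only, known or untested is meant among the compounds shown, and "the series" means these compounds.

Compound 1 (`CC(C)C1(C(C)C)CCOC1=O`): 137 mg/kg
Compound 2 (`CC1CCSC1=O`): 91 mg/kg

In a functional assay on the whole organism with Mus musculus as the target, in the maximal electroshock model (on this read-out lower numbers stand for an effect already at smaller amounts and higher numbers for an effect only at larger amounts of compound), compound 2 stands at 91 mg/kg and so lies within the usual scatter of compound 1, with no order to be read between them. Compound 3 (`CCC1CCSC1=O`) is not yet measured. It carries methyl in place of hydrogen on a saturated chain carbon bound to a saturated ring carbon, which amounts to methyl becoming ethyl. Going by the values given here, no measured pair shows this change, so the data offer no direct guide to its size. The expectation in this assay therefore starts from compound 2 at 91 mg/kg and assumes no step beyond the scatter, in either direction. The estimated step (a 1.1-fold lower number from compound 2 to compound 3 (0.03 log units; within the scatter)) is accordingly expected to be small. Compound 3 is expected at 85 mg/kg (estimated range 45 mg/kg to 160 mg/kg).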

Compound 3, dose for half-maximal effect: 232 mg/kg
Beside the measured number, compound 3's estimate is 2.7-fold (0.44 log units) below it, and the stated range ends below it.
By their numbers in this assay, from the lowest: compounds 2, 1 and 3 (each within the scatter of the next, the first and the last beyond it).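

In this assay, going by these compounds alone, the change from methyl to ethyl on a saturated chain carbon bound to a saturated ring carbon brings a 2.5-fold higher number from compound 2 to compound 3 (0.41 log units; beyond the scatter), the first step that can be read at all. It shows that this position is not indifferent to a single added carbon, and that here the change moves the effect toward larger amounts of compound, although this rests on one pair alone. Nothing shown gives a reason for the step.

From the compounds shown here alone, whether a longer chain such as propyl at this place would move the number further, or whether a hydroxyl or an amine on the ethyl group would bring it back toward that of compound 2, remains open. Compound 1 differs from compound 2 in more than one place, so it leaves open whether the same change would have a similar effect on its core.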